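The compounds below may be only part of what the source reports. "The series", "measured", "known", "first", "only" and "open" are said of these compounds alone.

Measured compounds:
compound 1 `CN(C)C(=O)c1cc2cnc(Nc3ccc(NC(=O)C4(C(=O)Nc5ccccc5)CC4)cc3)nc2n1C1CCCC1`: 88.8%
compound 2 `CN(C)C(=O)c1cc2cnc(Nc3ccc(NC(=O)C4(C(=O)Nc5ccccc5F)CC4)cc3)nc2n1C1CCCC1`: 88.6%
compound 3 `CN(C)C(=O)c1cc2cnc(Nc3ccc(NC(=O)C4(C(=O)Nc5ccc(C(F)(F)F)cc5)CC4)cc3)nc2n1C1CCCC1`: 87.9%

In a functional assay on A549 cells (Homo sapiens) for inhibition, read by CCK-8 assay, with a stated time of 72 h, tested at 10 uM (on this read-out higher numbers stand for more inhibition of growth at the one concentration tested and lower numbers for less inhibition of growth), compound 1 gives the highest of these three numbers, yet the steps of a number 0.2 percentage points lower from compound 1 to compound 2 (within the scatter) and a number 0.9 percentage points lower from compound 1 to compound 3 (within the scatter) both lie within the scatter, so the three compounds stand level. Compound 4 `COc1ccc(NC(=O)C2(C(=O)Nc3ccc(Nc4ncc5cc(C(=O)N(C)C)n(C6CCCC6)c5n4)cc3)CC2)cc1` differs from compound 1 by methoxy in place of hydrogen on an aromatic carbon. Within the data shown here, the steps that bear on this change are the two that put a group on the same aromatic ring, a number 0.2 percentage points lower from compound 1 to compound 2 (within the scatter) and a number 0.9 percentage points lower from compound 1 to compound 3 (within the scatter), and the swap between them, a number 0.7 percentage points lower from compound 2 to compound 3 (within the scatter); all were small. A step beyond the scatter in this assay is therefore not expected. Compound 4 is expected to give about 87%, most likely between 80% and 93%. That estimate means a step of a number 1.8 percentage points lower from compound 1 to compound 4 (within the scatter).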

Compound 4, percent growth inhibition at one concentration: 78.5%
For compound 4 the middle estimate is 8.5 percentage points above the measured one, and the stated range ends above it.
By their numbers in this assay, from the lowest: compounds 4, 3, 2 and 1 (each within the scatter of the next, the first and the last beyond it).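

The aromatic carbon that carries trifluoromethyl in compound 3 does not accept every group equally: in this assay, methoxy in place of hydrogen gives a number 10.3 percentage points lower from compound 1 to compound 4 (beyond the scatter). Replacing the 2-fluorophenyl group with 4-methoxyphenyl gives a number 10.1 percentage points lower from compound 2 to compound 4 (beyond the scatter), whereas methoxy in place of trifluoromethyl gives a number 9.4 percentage points lower from compound 3 to compound 4 (within the scatter), so those two compounds cannot be told apart. Nothing available explains the effect of methoxy.

From the compounds shown here alone, whether an amine, a hydroxyl group or a carboxylic acid at this carbon would match hydrogen or methoxy remains open.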